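A chloro-for-methoxy switch on compound 2

The source may report more compounds than this note shows. Statements on the series, on what has been measured and on what is new or still open speak of the compounds shown alone.

Compound 2 `COc1ccccc1N1CCN(CCCCCCN2C(=O)c3ccccc3S2(=O)=O)CC1` holds the lowest number of the three measured compounds in an assay on HEK293 cells for displacement of a labelled ligand from 5-hydroxytryptamine receptor 7 (Homo sapiens) (on this read-out lower numbers stand for stronger inhibition and higher numbers for weaker inhibition), giving 105 nM. Compound 1 `O=C1c2ccccc2S(=O)(=O)N1CCCCN1CCN(c2cccc(Cl)c2Cl)CC1` differs from compound 2 in several places; compound 1 gives 372 nM in this assay, a gap beyond the scatter. Compound 3 `O=C1c2ccccc2S(=O)(=O)N1CCCCCN1CCN(c2ncccn2)CC1` also differs from compound 2 in several places; compound 3 gives 2670 nM in this assay and stands furthest from compound 2. Compound 4 `O=C1c2ccccc2S(=O)(=O)N1CCCCCCN1CCN(c2ccc(Cl)cc2)CC1` has not yet been measured. It differs from compound 2 in a single place: 4-chlorophenyl in place of 2-methoxyphenyl on an amine nitrogen in a ring. For the measured compounds named here, no pair of measured compounds isolates this change, so the expectation rests on the three numbers alone. Compound 2 carries the 2-methoxyphenyl group and gives the lowest number, while compound 1 with a different aryl group gives a higher one, so an upward step beyond the scatter is expected; the step from compound 2 to compound 4 is expected to be a 2.9-fold higher number from compound 2 to compound 4 (0.46 log units; beyond the scatter) in this assay. Compound 4 is estimated at 300 nM in this assay, within a range from 100 nM to 900 nM.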

Compound 4, inhibition constant: 487 nM
Compound 4: middle estimate off by 1.6-fold (0.21 log units), on the low side; the range from low to high includes it.
By their numbers in this assay, from the lowest: compound 2; then compounds 1 and 4 (each within the scatter of the next); then compound 3.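

With the rest of the molecule unchanged, putting 4-chlorophenyl in place of 2-methoxyphenyl on the amine nitrogen in the ring gives a 4.6-fold higher number from compound 2 to compound 4 (0.67 log units; beyond the scatter) in this assay. For the compounds shown here, this step is modest, but it shows that the aryl group at this position alone can move the number beyond the scatter, which the earlier compounds could not show because each differs from the others in several places. Nothing measured here accounts for the size or direction of the step.

As far as these compounds go, it remains open whether the step follows from the loss of the methoxy group, the arrival of the chlorine or the different place of the substituent on the aryl ring, and an unsubstituted phenyl or 4-methoxyphenyl group would bear on this. From the compounds shown here alone, whether the same step holds with a shorter chain is also open.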